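The source may hold more compounds than are shown below. What is called first, only, known or untested is meant among the compounds shown, and "the series" means these compounds.

Compound 1 `CCCCN(C)C(=O)NS(=O)(=O)c1sc(CC(C)C)cc1-c1ccc(Cn2ccnc2)cc1`, compound 2 `CCCCOC(=O)NS(=O)(=O)c1sc(CCCC)cc1-c1ccc(Cn2ccnc2)cc1` and compound 3 `CCCCOC(=O)NS(=O)(=O)c1ccc(CCCC)cc1-c1ccc(Cn2ccnc2)cc1` share a core that carries a sulfonyl group joined to a carbonyl, and all three have been tested in an assay on membranes from uterus (Sus scrofa) for displacement of a labelled ligand from Type-2 angiotensin II receptor (Homo sapiens); a higher number here means a weaker inhibitor, a lower number a stronger inhibitor. In this assay compound 1 gives 4 nM, compound 2 gives 5 nM and compound 3 gives 5 nM. Compound 3 thus sits level with compound 2 at the digits shown, and its gap to compound 1 also stays within the usual scatter, so the three numbers cannot be told apart with confidence.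

Compound 4 `CCCCc1ccc(S(=O)(=O)NC(=O)OCC)c(-c2ccc(Cn3ccnc3)cc2)c1` has not yet been measured. It differs from compound 3 in one place: hydrogen in place of ethyl on a saturated chain carbon, two bonds along the chain from an oxygen next to a carbonyl group. Within the data shown here, no pair of measured compounds shows what a change of this kind does, so the expectation rests on the closeness of the three numbers alone. A small step in this assay, towards a weaker inhibitor but still close to the scatter, is expected, namely a 2.0-fold higher number from compound 3 to compound 4 (0.30 log units; within the scatter). For compound 4 the estimated value in this assay is 10 nM, with a range from 3 nM to 40 nM.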

Compound 4, inhibition constant: 2 nM
For compound 4 the middle estimate is 5.0-fold (0.70 log units) above the measured one; measured number below the stated range.
By their numbers in this assay, from the lowest: compounds 4, 1, 2 and 3 (each within the scatter of the next, the first and the last beyond it).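

Shortening the butoxy to ethoxy, which puts hydrogen in place of ethyl on a saturated chain carbon, two bonds along the chain from an oxygen next to a carbonyl group, gives in this assay a 2.5-fold lower number from compound 3 to compound 4 (0.40 log units; beyond the scatter), a modest step. Among these compounds, this is the first change at this position that can be read, and it shows that the outer ethyl is not needed for a low number here: the shorter chain gives the stronger inhibitor of this pair. No measurement shown gives a reason for this step.

Going by these compounds, whether a methoxy, a longer chain such as hexyloxy, or a carboxylic acid at the chain end would lower or raise the number remains open. So does whether the same shortening would give a similar step on the core of compound 2.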